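The source may report more compounds than this note shows. Statements on the series, on what has been measured and on what is new or still open speak of the compounds shown alone.

In a toxicity assay (Homo sapiens) for cytotoxicity, read by MTT assay, with a stated time of 48 h (a lower number here means a stronger inhibitor, a higher number a weaker inhibitor), three compounds of a shared core have been measured. Compound 1 `O=C1C(O)=C(C(c2ccccc2)c2c(-c3ccccc3)[nH]c3ccccc23)C(=O)c2ccccc21` gives 26400 nM. Compound 2 `COc1ccc(C(C2=C(O)C(=O)c3ccccc3C2=O)c2c[nH]c3ccccc23)cc1Br` gives 25200 nM. Compound 3 `Cc1[nH]c2ccccc2c1C(C1=C(O)C(=O)c2ccccc2C1=O)c1ccc(Cl)cc1` gives 40300 nM. On these numbers compound 2 stands alongside compound 1, the two figures falling within the usual scatter of each other, and its gap to compound 3 also lies within that scatter, so no ranking among the three can be read from these values.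

The step under consideration leads from compound 2 to compound 4 `COc1cccc(C(C2=C(O)C(=O)c3ccccc3C2=O)c2c[nH]c3ccccc23)c1`, which has not yet been measured in this assay. The change is 3-methoxyphenyl in place of 3-bromo-4-methoxyphenyl on a saturated chain carbon bound to an aromatic carbon and a double-bonded ring carbon. Among the measured compounds shown here, no measured pair in this set differs in the same way, so the size of the step cannot be taken from a measured comparison, and the three values available show no change beyond the scatter across differing aryl groups on that carbon.

On that basis the step of a 1.1-fold higher number from compound 2 to compound 4 (0.05 log units; within the scatter) is expected to stay within the scatter, with no direction favoured. Compound 4 is therefore estimated at 28000 nM in this assay, within a range from 12000 nM to 65000 nM.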

Compound 4, half-maximal inhibitory concentration: 110000 nM
For compound 4 the middle estimate is 3.9-fold (0.59 log units) below the measured one; measured number outside the range, above it.
By their numbers in this assay, from the lowest: compounds 2, 1 and 3 (each within the scatter of the next); then compound 4.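

In this assay the aryl group on this saturated chain carbon can move the number beyond the scatter: 3-methoxyphenyl in place of 3-bromo-4-methoxyphenyl gives a 4.4-fold higher number from compound 2 to compound 4 (0.64 log units; beyond the scatter), the only step shown that rests on a change in one place. The earlier compounds shown here differ in more than one place, so their closely grouped values could not show how much this position matters on its own, and this single pair now shows that it is not indifferent to the group it carries. The step belongs to the exchange as a whole, in which the bromine leaves and the methoxy group changes its number on the ring, and nothing available explains the rise.

From the compounds shown here alone, it remains open whether the step follows the bromine or the placing of the methoxy group, a question that a 3-bromophenyl or a 4-methoxyphenyl group on this carbon would help to separate. Also open, going by these compounds, is how an amine or a carboxylic acid on this aryl ring would read in this assay.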